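Fluorine Added to the Fused Ring of Compound 1

The source may hold more compounds than are shown below. What is called first, only, known or untested is meant among the compounds shown, and "the series" means these compounds.

Measured compounds:
Compound 1 `COc1cc2c(Oc3ccc(NC(=O)c4cc(-c5cccc(Cl)c5)nc5ccccc45)cc3F)ccnc2cc1OCCCN1CCC(C)CC1` gives 100 nM in a functional assay on HT-29 cells (Homo sapiens) for cytotoxicity, read by MTT assay, with a stated time of 72 h; a higher number here means a weaker inhibitor, a lower number a stronger inhibitor.
Compound 2 `COc1cc2c(Oc3ccc(NC(=O)c4cc(-c5ccccc5)nc5ccccc45)cc3F)ccnc2cc1OCCCN1CCC(C)CC1` gives 120 nM in this assay.

Compound 1 holds the lower of the two numbers, and compound 2 lies nearest, separated by a 1.2-fold higher number from compound 1 to compound 2 (0.08 log units; within the scatter), which says nothing about order. Compound 3 `COc1cc2c(Oc3ccc(NC(=O)c4cc(-c5cccc(Cl)c5)nc5ccc(F)cc45)cc3F)ccnc2cc1OCCCN1CCC(C)CC1` differs from compound 1 by fluoro in place of hydrogen on an aromatic carbon. Going by the values given here, no measured step touches this ring; the only step known, a 1.2-fold higher number from compound 1 to compound 2 (0.08 log units; within the scatter), concerns another ring and stays within the scatter. The expected outcome is a 1.1-fold higher number from compound 1 to compound 3 (0.04 log units; within the scatter), a step within the scatter. Compound 3 is estimated at 110 nM, ranging from 50 nM to 250 nM.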

Compound 3, half-maximal inhibitory concentration: 92 nM
Compound 3: the middle estimate sits 1.2-fold (0.08 log units) above what was measured, and the stated range covers the measured number.
By their numbers in this assay, from the lowest: compounds 3, 1 and 2 (each within the scatter of the next).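

Fluoro in place of hydrogen on this aromatic carbon brings a 1.1-fold lower number from compound 1 to compound 3 (0.04 log units; within the scatter) in this assay, so the number stays within the scatter. Going by these compounds alone, this is the first measured change on this ring of the shared core, and it shows that this carbon can carry a single fluorine without a readable shift in the number. No outside evidence bears on this result.

Going by these compounds, whether a methoxy group, an amine or a carboxylic acid on the same carbon would also leave the number unchanged remains open.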